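A piperidine amide in place of the morpholine amide

This account rests on a few compounds, and the source may have more. Where it says the series, first, only, none or still open, it means among the compounds named here.

The three measured compounds share one core, and they differ only in the group on a double-bonded ring carbon. Compound 1 `N#CC1=C(NCC(=O)N2CCOCC2)N(c2ccccc2)C(=O)N2CCCCC(N3CCCC3)C12` carries a (((morpholin-4-yl)carbonyl)methyl)amino group there, and in a functional assay on the whole organism (strain albino) for inhibition, with Rattus norvegicus as the target, read by paw edema, with stated times of 1 h and 2 h, at a dose of 20 mmol/kg by the intraperitoneal route (on this read-out lower numbers stand for less inhibition and higher numbers for more inhibition at the one dose given (going by the name of the read-out)), compound 1 gives 69.8%. Compound 2 `N#CC1=C(/N=C/Nc2ccc([N+](=O)[O-])cc2)N(c2ccccc2)C(=O)N2CCCCC(N3CCCC3)C12` gives 41.5%, while compound 3 `COc1ccc(/C=N/C2=C(C#N)C3C(N4CCCC4)CCCCN3C(=O)N2c2ccccc2)cc1` gives 71.6%. Compound 1 thus stands second highest of the three numbers; its nearest neighbour is reached by a number 1.8 percentage points higher from compound 1 to compound 3 (within the scatter), and its furthest by a number 28.3 percentage points lower from compound 1 to compound 2 (beyond the scatter).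

Compound 4 `N#CC1=C(NCC(=O)N2CCCCC2)N(c2ccccc2)C(=O)N2CCCCC(N3CCCC3)C12` has not yet been measured. Within the data shown here, its single difference from compound 1 is piperidin-1-yl in place of morpholin-4-yl on a carbonyl carbon. Among the measured compounds shown here, no measured step isolates this kind of change. The two steps starting from compound 1 exchange the whole group on the double-bonded ring carbon, one within the scatter and one beyond it, and the remaining step, a number 30.1 percentage points higher from compound 2 to compound 3 (beyond the scatter), swaps 4-methoxyphenyl for (4-nitrophenyl)amino. None of them tells how one saturated six-membered ring behaves against another on a carbonyl carbon. For the measured compounds named here, with no bearing step, the account expects no change beyond the scatter, so a number 1.8 percentage points lower from compound 1 to compound 4 (within the scatter) is the expected step. Compound 4 is therefore estimated at 68%, with a range from 54% to 80%.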

Compound 4, a percentage reported as inhibition, in the whole organism at one dose (the size of the read-out at that dose, not a potency): 46.1%
Beside the measured number, compound 4's estimate is 21.9 percentage points above it; measured number outside the range, below it.
By their numbers in this assay, from the lowest: compounds 2 and 4 (each within the scatter of the next); then compounds 1 and 3 (each within the scatter of the next).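

In this assay, the carbonyl carbon proves to be a place where the number responds: piperidin-1-yl in place of morpholin-4-yl keeps the count of heavy atoms unchanged, swaps one ring oxygen for carbon, and still gives a number 23.7 percentage points lower from compound 1 to compound 4 (beyond the scatter). The earlier compounds shown here showed only exchanges of the whole group on the double-bonded ring carbon, one of them within the scatter, whereas this change inside that group moves the number beyond it, and the new comparisons place the piperidine amide with the nitrophenyl compound, as a number 4.6 percentage points higher from compound 2 to compound 4 (within the scatter), and apart from the methoxyphenyl compound, as a number 25.5 percentage points lower from compound 3 to compound 4 (beyond the scatter). Nothing measured here gives a reason for this step.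

The compounds shown leave open whether the ring oxygen alone decides the outcome, which 4-methylpiperazin-1-yl or thiomorpholin-4-yl on the same carbonyl carbon could test, and whether an open-chain diethylamino group there would stay with compound 1 or with compound 4. They also leave open whether the step persists at other doses, since each number comes from a single dose.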